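From 4-methoxyphenyl to pyridin-2-yl: an expected small step

The source may hold more compounds than are shown below. What is called first, only, known or untested is meant among the compounds shown, and "the series" means these compounds.

In a functional assay on HeLa cells (Homo sapiens) for antiproliferative activity, read by sulforhodamine B assay, with a stated time of 48 h (a higher number here means a weaker inhibitor of growth, a lower number a stronger inhibitor of growth), compound 3 (`COc1ccc(-c2cn(CCCN3C(=O)COc4ccccc43)nn2)cc1`) gives 4900 nM and shares its core with compound 1 (`O=C1COc2ccccc2N1CCCn1cc(-c2ccccc2)nn1`), which gives 9000 nM in this assay as well. These two values lie within the scatter of each other, as the step of a 1.8-fold lower number from compound 1 to compound 3 (0.26 log units; within the scatter) shows, so neither ranks ahead. Compound 2 (`CCCCCc1ccc(-c2cn(CCCN3C(=O)COc4ccccc43)nn2)cc1`) gives only a limit of the assay (> 100000 nM) and no number. Two large steps involve that compound: an at least 11-fold higher number from compound 1 to compound 2 (1.04 log units; beyond the scatter) with pentyl in place of hydrogen, and an at least 20-fold lower number from compound 2 to compound 3 (1.30 log units; beyond the scatter) with methoxy in place of pentyl.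

In compound 4 (`O=C1COc2ccccc2N1CCCn1cc(-c2ccccn2)nn1`) pyridin-2-yl stands in place of 4-methoxyphenyl on an aromatic carbon (pyridin-2-yl in place of 4-methoxyphenyl on an aromatic carbon). Among the measured compounds shown here, no measured step introduces a ring with a hetero atom, so the support is indirect. The nearest guide is compound 1, whose unsubstituted ring differs from that of compound 3 by the step of a 1.8-fold lower number from compound 1 to compound 3 (0.26 log units; within the scatter) and stays within the scatter. Both large steps involve pentyl, which compound 4 does not carry. No change beyond the scatter is therefore expected in this assay, and any drift is expected toward a slightly higher number. The estimate is a 1.6-fold higher number from compound 3 to compound 4 (0.21 log units; within the scatter) as the expected step. Compound 4 is expected at an estimated 8000 nM with a range from 2500 nM to 30000 nM as its likely span.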

Compound 4, concentration for 50% growth inhibition: 10000 nM
Beside the measured number, compound 4's estimate is 1.3-fold (0.10 log units) below it; the range from low to high includes it.
By their numbers in this assay, from the lowest: compounds 3, 1 and 4 (each within the scatter of the next, the first and the last beyond it). At a limit, above all of these: compound 2.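

In this assay, pyridin-2-yl brings a ring with a hetero atom to this aromatic carbon on the five-membered ring, and it cannot be told apart from the phenyl it replaces: the step is a 1.1-fold higher number from compound 1 to compound 4 (0.05 log units; within the scatter). Set against 4-methoxyphenyl, the same ring gives a 2.0-fold higher number from compound 3 to compound 4 (0.31 log units; beyond the scatter), a modest step that lies just beyond the scatter and is the only step beyond it here that involves no pentyl, even though the step between the phenyl and 4-methoxyphenyl compounds stays within the scatter. The data shown offer no measurement that would explain either of these two steps.

On these data alone, it remains open how pyridin-3-yl or pyridin-4-yl would behave at this position, and so whether the place of the ring nitrogen matters to the number in this assay. Also open, as far as these compounds go, is whether an amine or a carboxylic acid on the aromatic ring would leave the number close to those of compound 1 and compound 4, and whether a shorter chain such as ethyl would already shift it in the way pentyl does in an at least 11-fold higher number from compound 1 to compound 2 (1.04 log units; beyond the scatter).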